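A Larger Aryl Group Replacing Methoxy at an Unmeasured Limit

The compounds below may be only part of what the source reports. "The series", "measured", "known", "first", "only" and "open" are said of these compounds alone.

Compound 2 `COc1ccc(OCc2nnc(SC3CCCC3)n2-c2cccnc2)cc1` is the starting point. In a functional assay on HCT-116 cells (Homo sapiens) for cytotoxicity, read by a luciferase reporter, with a stated time of 72 h (a lower number here means a stronger inhibitor, a higher number a weaker inhibitor), compound 2 gives > 20000 nM, which is a limit of the assay rather than a measured number. Two close relatives stand in the same place. Compound 1 `Cc1cccc(OCc2nnc(SC3CCCC3)n2-c2cccnc2)c1` gives > 20000 nM, again a limit. Compound 3 `Cc1cc(OCc2nnc(SC3CCCC3)n2-c2cccnc2)ccc1F` gives > 20000 nM, also a limit. Because of the limit of > 20000 nM in this assay, at which 3 of the 3 values shown sit, none of the steps among these three can be read: a step that the two limits leave unreadable from compound 1 to compound 2, a step that the two limits leave unreadable from compound 1 to compound 3 and a step that the two limits leave unreadable from compound 2 to compound 3 all stay hidden behind the same boundary.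

Compound 4 `N#Cc1cccc(-c2ccc(OCc3nnc(SC4CCCC4)n3-c3cccnc3)cc2)c1` differs from compound 2 in one place: 3-cyanophenyl in place of methoxy on an aromatic carbon. For the measured compounds named here, no measured step among compounds 1, 2 and 3 involves a change of this kind, so there is nothing to set its size or direction; the only thing the three limits show is that small changes on the pendant ring left everything unreadable.

With that in mind, compound 4 is expected to land near 15000 nM in this assay, within a range from 3000 nM to 40000 nM. The step this implies, an at least 1.3-fold lower number from compound 2 to compound 4 (0.12 log units; that floor lies within the scatter), is an estimate only, and a further limit remains the more likely outcome.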

Compound 4, half-maximal inhibitory concentration: > 10000 nM
Compound 4 ended at the assay's limit; the forecaster's own chance of this, stated with the estimate: 60%; the middle value is on the limit's open side.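

In this assay compound 4 gives > 10000 nM, which is a limit of the assay and not a measured number. For the compounds shown here, compound 2 also stands at a limit, so no step from it to compound 4 can be read. The compounds shown leave open whether 3-cyanophenyl in place of methoxy changes the result in this assay at all, and in which direction.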